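The source may hold more compounds than are shown below. What is called first, only, known or untested is meant among the compounds shown, and "the series" means these compounds.

Compound 1 `CCCC/C=C\CCCCCCCCCc1cc(=O)c2c(O)cc(OCOC)cc2o1` gives > 87000 nM
Compound 2 `CC/C=C\C/C=C\C/C=C\CCCCCCCc1cc(=O)c2c(O)cc(OCOC)c(C)c2o1` gives 6790 nM

For the measured compounds named here, in a functional assay on MDA-MB-231 cells (Homo sapiens) for antiproliferative activity, read by MTT assay (a lower number here means a stronger inhibitor, a higher number a weaker inhibitor), compound 2 gives 6790 nM as the only true number so far. Compound 1 is reported only as the limit > 87000 nM and not as a number.

Compound 3 `CCCC/C=C\CCCCCCCCCc1cc(=O)c2c(O)cc(OCOC)c(C)c2o1` has not yet been measured. It differs from compound 2 by a group of 8 heavy atoms (8 carbon; no ring) in place of a group of 10 heavy atoms (10 carbon; no ring), on a saturated chain carbon, seven bonds along the chain from an aromatic carbon and in nothing else, so the core stays the same and only the chain changes.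

Going by the values given here, no measured pair in this assay shows this kind of change, so the size of the step has to be judged from little. Compound 1 carries the same oct-3-en-1-yl group and its reading is the limit > 87000 nM while its core differs from that of compound 2. This is a loose guide, but it points toward a weaker inhibitor, and a reading that is only a limit remains possible.

The step expected in size and direction is a 2.7-fold higher number from compound 2 to compound 3 (0.42 log units; beyond the scatter) toward a higher number. The estimate for compound 3 is 18000 nM with an expected range from 5000 nM to 65000 nM for the measurement.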

Compound 3, half-maximal inhibitory concentration: > 87000 nM
Compound 3: no number, only a limit (the forecaster's own chance of this, stated with the estimate: 30%); middle value at least 4.8-fold (0.68 log units) away from the limit.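

In this assay, placing oct-3-en-1-yl where the group of 10 heavy atoms with 3 double bonds stood, on a saturated chain carbon, seven bonds along the chain from an aromatic carbon, gives an at least 12-fold higher number from compound 2 to compound 3 (1.10 log units; beyond the scatter), a large step with a limit and not a number at one end. The earlier compounds shown here differed in their cores as well as their chains, whereas this pair shares one core and differs only in the chain, so the loss of measurable activity follows the chain change alone. With this result, both compounds that carry oct-3-en-1-yl end at the same limit: the limit of > 87000 nM in this assay, at which 2 of the 3 values shown sit.

On these data alone, the step from compound 1 to compound 3, methyl in place of hydrogen on an aromatic carbon, cannot be read, as both ends are limits, so any effect of that methyl alongside oct-3-en-1-yl stays unknown. The two chains also differ in both length and number of double bonds, and these compounds cannot separate the two; a fully saturated chain of either length, a longer chain, or a chain ending in a carboxylic acid would test the position further.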